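Methyl for Hydrogen on Oxygen: Two Parallel Steps

A few compounds are considered here, and "the series" means these few. Any claim that something is new, unique, unknown or untested is made for them only; others in the source may bear on it.

Three compounds have been measured in a functional assay on HEK293 cells with D(4) dopamine receptor (Homo sapiens) as the target, read by FLIPR; on this read-out higher numbers stand for larger maximal responses and lower numbers for smaller maximal responses:
compound 1 `CO/N=C(/c1ccc(Cl)cc1)C(O)CN1CCN(c2ccccn2)CC1`, 94%
compound 2 `CO/N=C(/c1ccc(Cl)cc1)C(CN1CCN(c2ccccn2)CC1)OC`, 83%
compound 3 `Cc1cccc(/C(=N\O)C(O)CN2CCN(c3ccccn3)CC2)c1`, 66%

Compound 1 and compound 2 differ in one place, (methyl in place of hydrogen on an oxygen on a saturated carbon), and this gave a number 11 percentage points lower from compound 1 to compound 2 (beyond the scatter). Compound 3 stands lowest of the three; its number lies beyond the scatter below both compound 1 and compound 2. How the core of compound 3 differs from that of compound 1 is not broken down here.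

Compound 4 `COC(CN1CCN(c2ccccn2)CC1)/C(=N/O)c1cccc(C)c1` is not yet measured. For the measured compounds named here, it differs from compound 3 by methyl in place of hydrogen on an oxygen on a saturated carbon, which is the same kind of change as the one from compound 1 to compound 2, and the place is described in the same words in both cases. This is the only earlier instance of the change among the compounds shown, so the expectation rests on a single step. Compound 4 is therefore expected to show a step of about a number 11 percentage points lower from compound 3 to compound 4 (beyond the scatter) in this assay, because the same change gave a number 11 percentage points lower from compound 1 to compound 2 (beyond the scatter). On that basis the maximal response of compound 4 is estimated at 55%, within a range from 40% to 70%.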

Compound 4, largest response reached (reported as efficacy), in percent of the reference or control that the assay uses: 53%
Compound 4: middle estimate off by 2 percentage points, on the high side; low and high end bracket the measured number.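

In this assay the change from hydroxy to methoxy gave a number 13 percentage points lower from compound 3 to compound 4 (beyond the scatter) and, set beside the earlier step, it came out the same in size on both cores: the same change on two cores in this assay, a number 11 percentage points lower (beyond the scatter) from compound 1 to compound 2 and a number 13 percentage points lower (beyond the scatter) from compound 3 to compound 4, 2 percentage points apart, within the scatter of two such steps. This shows that, for these two pairs, the change lowered the maximal response by a similar amount, so the step seen on the core of compound 1 carried over to the core of compound 3. It does not show that the step would hold on any other core in the series, since two pairs are a small base, and it does not tell why the response falls.

The compounds shown leave open how the maximal response would move if an ethyl group or a longer chain took the place of the methyl on that oxygen. They also leave open what an amine or a fluorine in place of the hydroxy would do on either core.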